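Endoperoxide acid diastereomers: stereochemistry step toward compound 4

This account rests on a few compounds, and the source may have more. Where it says the series, first, only, none or still open, it means among the compounds named here.

Working notes on a small set tested in a functional assay on MDA-MB-231 cells (Homo sapiens) for inhibition; a higher number here means a weaker inhibitor of growth, a lower number a stronger inhibitor of growth. Compound 1 `CC(=O)CC/C=C(\C)CCC1=C(C)CCCC1(C)C` is an open-chain ketone without the endoperoxide ring; in this assay compound 1 returns only the limit > 15000 nM, not a number. Compound 3 `CC1=C(CC/C(C)=C/CC[C@@]2(C)CC[C@@H]([C@H](C)C(=O)O)OO2)C(C)(C)CCC1` carries the endoperoxide acid on a longer chain; in this assay compound 3 likewise reaches only the limit > 100000 nM. Compound 2 `C=C1CCCC(C)(C)C1CC[C@]1(C)CC[C@@H]([C@@H](C)C(=O)O)OO1` is the shorter endoperoxide acid with the exocyclic methylene; in this assay compound 2 gives only the limit > 10000 nM. So compound 2 stands nowhere definite on the numbers shown: every value in the set is a limit of > 10000 nM in this assay, at which 1 of the 3 values shown sits, the limit of > 100000 nM in this assay, at which 1 of the 3 values shown sits (the limit of > 15000 nM in this assay, at which 1 of the 3 values shown sits), and no step between measured compounds can be drawn.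

Compound 4 `C=C1CCCC(C)(C)C1CC[C@@]1(C)CC[C@H]([C@@H](C)C(=O)O)OO1` differs from compound 2 only in configuration: the two compounds have the same atoms and bonds; at least one stereo element is drawn with a configuration in one of them and without one in the other: 2 of 4 stereo elements differ; a stereocentre at a saturated ring carbon is drawn R in compound 2 and S in compound 4; a stereocentre at a saturated ring carbon is drawn S in compound 2 and R in compound 4. For the measured compounds named here, with no measured step to lean on, the step from compound 2 to compound 4 is expected to be none beyond the scatter, a step that the limit leaves unreadable from compound 2 to compound 4. Compound 4 is expected to give about 20000 nM in this assay, within 5000 nM to 80000 nM, most probably again as a limit.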

Compound 4, concentration for 50% growth inhibition: 7440 nM
The estimate for compound 4 lay 2.7-fold (0.43 log units) above the measured number; measured number inside the range.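

In this assay, for the compounds shown here, compound 4 gives 7440 nM, the first value in the set that is a number and not a limit. Compound 2 stays at > 10000 nM, which is a limit. With atoms and bonds unchanged and only the two saturated ring carbons differing in configuration, the change gives an at least 1.3-fold lower number from compound 2 to compound 4 (0.12 log units; that floor lies within the scatter), so configuration alone separates a number from a limit here, though the printed floor does not establish a change beyond the scatter.

From the compounds shown here alone, the true size of this step stays open, and its reading as a pure stereochemical comparison carries one caution: the fact that one of compounds 2 and 4 is drawn with a defined configuration and the other without, at the place where they differ. Also open, going by these compounds, is how compound 4 would read in this assay with a methyl ester in place of the carboxylic acid.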